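The compounds below may be only part of what the source reports. "The series", "measured", "known", "first", "only" and "open" are said of these compounds alone.

Three compounds built on one shared core were tested in an ADME assay on TZM-b1 cells (Homo sapiens) for cytotoxicity, read by XTT assay, with a stated time of 3 days; on this read-out lower numbers stand for higher toxicity in this test and higher numbers for lower toxicity in this test. Compound 2 `CC(=O)N1CCCCC1C(NC(=O)C(=O)Nc1ccc(Cl)cc1)c1nc(C)c(CCO)s1` stands at a limit of the test rather than at a number: in this assay compound 2 gives > 84000 nM, a ceiling, as the limit of > 84000 nM in this assay, at which 1 of the 3 values shown sits, records. Compound 1 `Cc1nc(C(NC(=O)C(=O)Nc2ccc(F)cc2)C2CCCCN2)sc1CCO` likewise stops at a limit, giving > 88000 nM in this assay. Compound 3 `CC(=O)c1ccc(NC(=O)C(=O)NC(c2nc(C)c(CO)s2)C2CCCCN2)cc1` too is held at a limit, with > 86000 nM in this assay. None of the three separates from the others. Compound 4 `Cc1nc(C(NC(=O)C(=O)Nc2ccc(Cl)cc2)C2CCCCN2)sc1CCO` differs from compound 2 in one place: hydrogen in place of acetyl on an amine nitrogen in a ring. Because compound 1 with the same free ring nitrogen also gives > 88000 nM in this assay, the step from compound 2 to compound 4 is expected to stay within the scatter, a step that the limit leaves unreadable from compound 2 to compound 4. Compound 4 is estimated at 90000 nM in this assay, between 60000 nM and 150000 nM, most likely again reported only as a limit.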

Compound 4, half-maximal cytotoxic concentration: 32800 nM
Beside the measured number, compound 4's estimate is 2.7-fold (0.44 log units) above it; the whole stated range lies above it.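

In this assay compound 4 gives a true number rather than a limit, so this ring nitrogen matters: hydrogen in place of acetyl gives an at least 2.5-fold lower number from compound 2 to compound 4 (0.40 log units; beyond the scatter) in this read-out. With hydrogen on that nitrogen, the halogen on the aromatic carbon matters too: chloro in place of fluoro gives an at least 2.6-fold lower number from compound 1 to compound 4 (0.42 log units; beyond the scatter) here. Nothing measured here explains either step. From the compounds shown here alone, it stays open whether a methyl or a benzoyl group on the ring nitrogen would keep the number low or return it to a limit. Going by these compounds, whether bromo on the aromatic carbon would follow chloro is equally open.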